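The source may hold more compounds than are shown below. What is called first, only, known or untested is meant among the compounds shown, and "the series" means these compounds.

Measured in a functional assay on CHO cells for antagonist activity at prostaglandin E2 receptor EP3 subtype (Homo sapiens), read by cAMP accumulation; a higher number here means a weaker inhibitor, a lower number a stronger inhibitor:
- compound 1, `CC(C)C(c1nnc[nH]1)c1ccc(-c2ccc3cccc(F)c3c2)[nH]c1=O`: 21 nM
- compound 2, `CC(C)C(c1ccc(-c2ccc3cccc(F)c3c2)[nH]c1=O)N1CCCCC1=O`: 40 nM
- compound 3, `CC(C)C(Cc1nnn[nH]1)c1ccc(-c2ccc3cccc(F)c3c2)[nH]c1=O`: 134 nM

Compound 3 gives the highest number of the three. The steps of a 6.4-fold higher number from compound 1 to compound 3 (0.80 log units; beyond the scatter) and a 3.4-fold higher number from compound 2 to compound 3 (0.53 log units; beyond the scatter) both lie beyond the scatter, whereas the step of a 1.9-fold higher number from compound 1 to compound 2 (0.28 log units; within the scatter) stays within it, so compound 1 and compound 2 cannot be ordered against each other.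

Compound 4, `CC(C)C(c1ccc(-c2ccc3cccc(F)c3c2)[nH]c1=O)N1CCCCS1(=O)=O`, is not yet measured. The change from compound 3 is a group of 8 heavy atoms (4 carbon, 1 nitrogen, 2 oxygen, 1 sulfur; one six-membered non-aromatic ring with 2 hetero atoms) in place of a group of 6 heavy atoms (2 carbon, 4 nitrogen; one five-membered aromatic ring with 4 hetero atoms), on a saturated chain carbon bound to an aromatic carbon and a saturated chain carbon. The entering group, like the 2-oxopiperidin-1-yl of compound 2, is a six-membered non-aromatic ring on the same saturated chain carbon, so the step that bears most directly is the reverse of a 3.4-fold higher number from compound 2 to compound 3 (0.53 log units; beyond the scatter): exchanging the (1H-tetrazol-5-yl)methyl for a six-membered non-aromatic ring gave a lower number there, of modest size. Among the compounds with values here, no step involving the entering group itself is available, so the expectation rests on that single precedent and carries a wide range. A lower number for compound 4 than for compound 3 is therefore expected, with an expected step of a 2.7-fold lower number from compound 3 to compound 4 (0.43 log units; beyond the scatter). Compound 4 is estimated at 50 nM, with a range of 18 nM to 150 nM.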

Compound 4, half-maximal inhibitory concentration: 122 nM
The estimate for compound 4 lay 2.4-fold (0.39 log units) below the measured number; low and high end bracket the measured number.
By their numbers in this assay, from the lowest: compounds 1 and 2 (each within the scatter of the next); then compounds 4 and 3 (each within the scatter of the next).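

In this assay, a six-membered non-aromatic ring on this saturated chain carbon does not by itself give the lower number seen with the 2-oxopiperidin-1-yl: a 1.1-fold lower number from compound 3 to compound 4 (0.04 log units; within the scatter), so the entering ring cannot be told apart from the (1H-tetrazol-5-yl)methyl, while a 3.1-fold higher number from compound 2 to compound 4 (0.48 log units; beyond the scatter). The position therefore distinguishes between two rings of the same size, and a 5.8-fold higher number from compound 1 to compound 4 (0.76 log units; beyond the scatter), which leaves the 4H-1,2,4-triazol-3-yl and the 2-oxopiperidin-1-yl as the two groups giving the lowest numbers. Nothing available here explains the difference between the two six-membered rings.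

From the compounds shown here alone, it remains open how a plain piperidin-1-yl ring without the carbonyl, or a morpholin-4-yl ring, would compare with compound 2 and compound 4. Also open, going by these compounds, is whether a (4H-1,2,4-triazol-3-yl)methyl group would follow compound 1 or compound 3.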